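Chiral bicyclic side chain replaces the open terpene chain

The source may hold more compounds than are shown below. What is called first, only, known or untested is meant among the compounds shown, and "the series" means these compounds.

Compound 3 `CC(C)=CCCC(C)CCOc1ccc(C2SCC(=O)N2Cc2ccccc2)cc1` carries an open, partly unsaturated chain on the oxygen of its aromatic ring, and in a toxicity assay on HeLa cells (Homo sapiens) for cytotoxicity (a lower number here means that less compound is tolerated, a higher number that more compound is tolerated), compound 3 shows "nd" (no result reported). Its closest measured relatives share the same core. Compound 1 `CC(C)CCCC(C)CCOc1ccc(C2SCC(=O)N2Cc2ccccc2)cc1` carries a fully saturated chain at that position, and in this assay compound 1 gives 66000 nM. Compound 2 `CC(C)=CCC/C(C)=C/COc1ccc(C2SCC(=O)N2Cc2ccccc2)cc1` carries a chain with two double bonds, and for compound 2 this assay reports only a limit, > 100000 nM. For the measured compounds named here, the step of an at least 1.5-fold higher number from compound 1 to compound 2 (0.18 log units; that floor lies within the scatter) is therefore bounded only on one side, and its floor sits within the usual scatter, so the two measured chains cannot be told apart with confidence; the only evidence is the limit of > 100000 nM in this assay, at which 1 of the 3 values shown sits. Compound 4 `CC1(C)C2CC=C(COc3ccc(C4SCC(=O)N4Cc4ccccc4)cc3)C1C2` differs from compound 3 in one place: a group of 9 heavy atoms (9 carbon; one four-membered non-aromatic ring of carbon only, one six-membered non-aromatic ring of carbon only) in place of a group of 9 heavy atoms (9 carbon; no ring), on a saturated chain carbon bound to an oxygen on an aromatic ring. Neither measured step covers a change from an open chain to a fused bicyclic group, so no shift beyond the scatter is expected in this assay from compound 3 to compound 4. Given that both measured values are weak, compound 4 is expected to sit near 80000 nM, within a range from 30000 nM to 200000 nM.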

Compound 4, half-maximal cytotoxic concentration: 74000 nM
Compound 4: middle estimate off by 1.1-fold (0.03 log units), on the high side; the measured number falls inside the stated range.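

In this assay, compound 4 puts a group with rings at this position, on a saturated chain carbon bound to an oxygen on an aromatic ring, where the other compounds shown carry open chains. Against the fully saturated chain the result is a 1.1-fold higher number from compound 1 to compound 4 (0.05 log units; within the scatter), so replacing that open chain with a group containing one four-membered and one six-membered carbon ring, with the same count of heavy atoms, leaves no difference that can be told from scatter. The comparison with the chain carrying two double bonds, an at least 1.3-fold lower number from compound 2 to compound 4 (0.13 log units; that floor lies within the scatter), has only a floor, since the value of compound 2 is a limit, and it therefore does not separate these two groups: the limit of > 100000 nM in this assay, at which 1 of the 4 values shown sits.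

The compounds shown leave open whether a different kind of group at this position, such as an amine, a carboxylic acid or a much shorter chain, would move the number beyond the scatter. With no result reported for compound 3, the comparison between its 2,6-dimethylhept-5-en-1-yl chain and the bicyclic group of compound 4 also stays unread.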